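The compounds below may be only part of what the source reports. "The series", "measured", "known", "first", "only" and "open" are said of these compounds alone.

In a functional assay on the whole organism with Rattus norvegicus as the target (on this read-out lower numbers stand for an effect already at smaller amounts and higher numbers for an effect only at larger amounts of compound), compound 1 `Cn1c(=N)sc2cc(OC(F)(F)F)ccc21` gives 5 mg/kg and compound 2 `C=CCn1c(=N)sc2cc(OC(F)(F)F)ccc21` gives 7 mg/kg. These two differ by a 1.4-fold higher number from compound 1 to compound 2 (0.15 log units; within the scatter). Compound 3 `N=c1sc2cc(OC(F)(F)F)ccc2n1CCS(=O)(=O)O`, which carries 2-sulfoethyl on the shared core, reads > 10 mg/kg, and that is a limit of the assay, not a number. The comparisons with it are an at least 2.0-fold higher number from compound 1 to compound 3 (0.30 log units; that floor lies within the scatter) and an at least 1.4-fold higher number from compound 2 to compound 3 (0.15 log units; that floor lies within the scatter), so compound 3 cannot be firmly set apart from the other two.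

Compound 4 `CS(=O)(=O)CCn1c(=N)sc2cc(OC(F)(F)F)ccc21` has methyl in place of hydroxy on a sulfonyl sulfur, which turns 2-sulfoethyl into 2-(methylsulfonyl)ethyl. Going by the values given here, no measured step makes this exact change. The closest guides are the two steps into compound 3 and a 1.4-fold higher number from compound 1 to compound 2 (0.15 log units; within the scatter), none shown beyond the scatter, so in this assay a modest move to a lower number, or none beyond the scatter, is expected. The estimated change is an at least 1.2-fold lower number from compound 3 to compound 4 (0.09 log units; that floor lies within the scatter). For compound 4 the expected value is 8 mg/kg, within an estimated range of 3 mg/kg to 20 mg/kg.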

Compound 4, dose for half-maximal effect: 1.8 mg/kg
For compound 4 the middle estimate is 4.4-fold (0.65 log units) above the measured one; the whole stated range lies above it.
By their numbers in this assay, from the lowest: compound 4; then compounds 1 and 2 (each within the scatter of the next). At a limit, above all of these: compound 3.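

In this assay, going by these compounds alone, methyl in place of hydroxy on a sulfonyl sulfur gives an at least 5.5-fold lower number from compound 3 to compound 4 (0.74 log units; beyond the scatter), the first step printed as beyond the scatter. Its true size may be larger, because compound 3 stands at a limit and not at a number: the limit of > 10 mg/kg in this assay, at which 1 of the 4 values shown sits. The 2-(methylsulfonyl)ethyl group also sets compound 4 apart from the two other measured neighbours, with a 3.9-fold lower number from compound 2 to compound 4 (0.59 log units; beyond the scatter) and a 2.8-fold lower number from compound 1 to compound 4 (0.44 log units; beyond the scatter), so a change at this place can bring a clearly lower number, although the groups of compound 2 and compound 3 show no such gain.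

As far as these compounds go, whether a carboxylic acid, an amine or a longer chain ending in methylsulfonyl would read like compound 4 stays open. The compounds shown also do not tell what in the whole animal lies behind the lower number of compound 4.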